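This account rests on a few compounds, and the source may have more. Where it says the series, first, only, none or still open, it means among the compounds named here.

Compound 1 `CCCC(CCC)n1c(-c2ccc(OCc3c(-c4c(Cl)cccc4Cl)noc3C(C)C)cc2)nc2ccc(C(=O)O)cc21` shows only a limit in an assay on HEK-293T cells for antagonist activity at vitamin D3 receptor (Homo sapiens), read by a luciferase reporter, with a stated time of 24 h (on this read-out higher numbers stand for weaker inhibition and lower numbers for stronger inhibition), > 10000 nM. Among the measured compounds shown here, compound 2 `CC(C)c1onc(-c2c(Cl)cccc2Cl)c1COc1ccc(-c2nc3ccc(C(=O)O)cc3n2C(C)C)cc1` gives 3550 nM in this assay, the only measured number in the set, since the limit of > 10000 nM in this assay, at which 1 of the 2 values shown sits, holds the other value. For the measured compounds named here, the one measured change on the ring nitrogen is an at least 2.8-fold lower number from compound 1 to compound 2 (0.44 log units; beyond the scatter). Compound 3 `CC(C)c1onc(-c2c(Cl)cccc2Cl)c1COc1ccc(-c2nc3ccc(C(=O)O)cc3n2C2CCC2)cc1` carries cyclobutyl in place of isopropyl on an aromatic nitrogen. Cyclobutyl sits in size between isopropyl and 1-propylbutyl, so a small rise in the number is expected, because the shrinking group in an at least 2.8-fold lower number from compound 1 to compound 2 (0.44 log units; beyond the scatter) went with a lower number; the expected step is a 1.3-fold higher number from compound 2 to compound 3 (0.10 log units; within the scatter). For compound 3 the estimate is 4500 nM, between 2000 nM and 12000 nM.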

Compound 3, half-maximal inhibitory concentration: 1100 nM
Compound 3: the middle estimate sits 4.1-fold (0.61 log units) above what was measured; the measured number lies below the stated range.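

At this position, on an aromatic nitrogen, the number no longer simply falls as the group gets smaller: cyclobutyl in place of isopropyl gives a 3.2-fold lower number from compound 2 to compound 3 (0.51 log units; beyond the scatter), and compound 3 is the strongest of the three. A ring of carbon is thus preferred here over open branching, on the evidence of this single pair. The full span, an at least 9.0-fold lower number from compound 1 to compound 3 (0.95 log units; beyond the scatter), is only a bound, as compound 1 rests on a limit: the limit of > 10000 nM in this assay, at which 1 of the 3 values shown sits.

Going by these compounds, whether the drop follows the ring itself or simply the carbon count stays open. Cyclopropyl, cyclopentyl or oxetanyl on the same nitrogen would separate the two.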